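Adding a methoxy group to compound 2

This account rests on a few compounds, and the source may have more. Where it says the series, first, only, none or still open, it means among the compounds named here.

Measured compounds:
Compound 1 `CC1(C)CC(NC(=O)Nc2ccccc2Cl)c2cc(Br)ccc2O1`: 19000 nM
Compound 2 `O=[N+]([O-])c1cccc(NC(=S)NCc2cccc(Cl)c2)c1`: 32000 nM

In a functional assay on U-373MG ATCC cells (Homo sapiens) for inhibition, read by MTT assay, with a stated time of 72 h (a lower number here means a stronger inhibitor, a higher number a weaker inhibitor), compound 2 gives 32000 nM. Compound 1 gives 19000 nM, and the two values lie within the scatter of each other. Compound 3 `COc1ccc(Cl)cc1CNC(=S)Nc1cccc([N+](=O)[O-])c1` is compound 2 with one change: methoxy in place of hydrogen on an aromatic carbon. Methoxy stands in place of hydrogen on an aromatic carbon, ortho to a large group and para to a chloro group. For the measured compounds named here, no measured pair shows this change, so no step beyond the scatter is expected in this assay. The expected result is a 1.3-fold lower number from compound 2 to compound 3 (0.11 log units; within the scatter). Compound 3 is estimated at 25000 nM, with an expected range from 10000 nM to 60000 nM.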

Compound 3, half-maximal inhibitory concentration: 32000 nM
Compound 3: middle estimate off by 1.3-fold (0.11 log units), on the low side, within the range that was stated.
By their numbers in this assay, from the lowest: compounds 1, 2 and 3 (each within the scatter of the next).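

In this assay, for the compounds shown here, methoxy in place of hydrogen on an aromatic carbon, ortho to a large group and para to a chloro group, brings no change at the digits printed from compound 2 to compound 3 (within the scatter) and gives the first reading of this change at this position. This carbon therefore carries methoxy with no step beyond the scatter. Nothing available explains this result.

From the compounds shown here alone, whether an amine, a carboxylic acid or a longer chain on this carbon would move the number beyond the scatter remains open. So does whether methoxy would give the same result on another carbon of this ring.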